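Stability of an Aryl Thiol Among Three Electrophilic Analogues

The compounds below may be only part of what the source reports. "The series", "measured", "known", "first", "only" and "open" are said of these compounds alone.

Measured so far:
compound 1 `C=CS(=O)(=O)c1cc(C(F)(F)F)cc(C(F)(F)F)c1` with < 0.017 h
compound 2 `O=C1C=CC(=O)N1c1cc(C(F)(F)F)cc(C(F)(F)F)c1` with < 0.017 h
compound 3 `O=C(CBr)c1cc(C(F)(F)F)cc(C(F)(F)F)c1` with < 0.017 h

Compound 3 stands at a limit of the assay in an ADME assay for pharmacokinetics, read by LC-MS, in phosphate buffer, with a stated time of 72 h, at pH 7.4, tested at 250 uM (a higher number here means that the compound lasts longer, a lower number that the compound disappears faster), rather than at a number. In this assay compound 1 also gives only a limit, < 0.017 h. In this assay compound 2 likewise gives only a limit, < 0.017 h. All three values sit at the same limit (the limit of < 0.017 h in this assay, at which 3 of the 3 values shown sit), so the three steps that join these compounds, a step that the two limits leave unreadable from compound 1 to compound 2, a step that the two limits leave unreadable from compound 1 to compound 3 and a step that the two limits leave unreadable from compound 2 to compound 3, cannot be read for size or direction.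

Compound 4 `FC(F)(F)c1cc(S)cc(C(F)(F)F)c1` differs from compound 3 in one place: sulfanyl in place of (bromomethyl)carbonyl on an aromatic carbon. For the measured compounds named here, no measured step reaches a number, so none of the measured steps gives a readable size for this change. The only ground for an expectation is that the three measured compounds, each carrying a different group on the shared core, all fall at the limit, and compound 4 carries a sulfanyl group instead. Compound 4 is expected to show a step of an at least 470-fold higher number from compound 3 to compound 4 (2.67 log units; beyond the scatter) in this assay, with wide uncertainty. The half-life of compound 4 in this assay is estimated at 8 h, within a range from 0.5 h to 72 h.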

Compound 4, half-life: > 50 h
Compound 4 ended at the assay's limit (the forecaster's own chance of this, stated with the estimate: 30%); middle value at least 6.2-fold (0.79 log units) away from the limit.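

Sulfanyl on this aromatic carbon is the only one of the four groups shown that moves the compound off the short limit in this assay, giving an at least 2900-fold higher number from compound 3 to compound 4 (3.46 log units; beyond the scatter). The same holds against the other two groups, with an at least 2900-fold higher number from compound 2 to compound 4 (3.46 log units; beyond the scatter) and an at least 2900-fold higher number from compound 1 to compound 4 (3.46 log units; beyond the scatter), so the position does not fix the outcome on its own, although the steps among compound 1, compound 2 and compound 3 remain unreadable. Compound 4 gives > 50 h, which is a limit of the assay and not a number.

From the compounds shown here alone, how far the half-life of compound 4 lies beyond that limit therefore stays open, and so does the full size of all three steps. Also open, going by these compounds, is where other groups at this place, such as an amine, a hydroxyl or a carboxylic acid, would fall in this assay.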